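Removing One Chloro from the 2,6-Dichlorophenyl Compound

The source may hold more compounds than are shown below. What is called first, only, known or untested is meant among the compounds shown, and "the series" means these compounds.

In a functional assay on QG-56 cells (Homo sapiens) for cytotoxicity, read by MTT assay, with a stated time of 48 h (a higher number here means a weaker inhibitor, a lower number a stronger inhibitor), three compounds sharing one core have been measured. Compound 1 `COc1cc(/C=C/C(=O)C2=C(/C=C/c3ccc(O)c(OC)c3)NC(=O)NC2c2ccc(O)cc2)ccc1O` gives 50000 nM, compound 2 `COc1cc(/C=C/C(=O)C2=C(/C=C/c3ccc(O)c(OC)c3)NC(=O)NC2c2ccc(N(C)C)cc2)ccc1O` gives 12500 nM, and compound 3 `COc1cc(/C=C/C(=O)C2=C(/C=C/c3ccc(O)c(OC)c3)NC(=O)NC2c2c(Cl)cccc2Cl)ccc1O`, which carries 2,6-dichlorophenyl, gives 100000 nM. The comparisons show a 2.0-fold higher number from compound 1 to compound 3 (0.30 log units; within the scatter) and an 8.0-fold higher number from compound 2 to compound 3 (0.90 log units; beyond the scatter). Compound 3 therefore cannot be separated from compound 1, but it is clearly weaker than compound 2.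

Compound 4 `COc1cc(/C=C/C(=O)C2=C(/C=C/c3ccc(O)c(OC)c3)NC(=O)NC2c2ccccc2Cl)ccc1O` turns 2,6-dichlorophenyl into 2-chlorophenyl: hydrogen in place of chloro on an aromatic carbon. Among the measured compounds shown here, no measured step removes a single chloro, so the evidence is indirect. The closest comparisons exchange the whole aromatic group at the same place. One is the step above to compound 3 from compound 2, and another is a 4.0-fold lower number from compound 1 to compound 2 (0.60 log units; beyond the scatter). Even these larger exchanges gave only modest steps, and the exchange with compound 1, a 2.0-fold higher number from compound 1 to compound 3 (0.30 log units; within the scatter), stayed within the scatter. A smaller change is thus expected to move the number little. The expected step is a 1.7-fold lower number from compound 3 to compound 4 (0.22 log units; within the scatter), a slight move towards a lower number that would not go beyond the scatter. For compound 4 the estimated value is 60000 nM, with an expected range from 25000 nM to 130000 nM.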

Compound 4, half-maximal inhibitory concentration: 100000 nM
Compound 4: middle estimate off by 1.7-fold (0.22 log units), on the low side; measured number inside the range.
By their numbers in this assay, from the lowest: compound 2; then compounds 1, 3 and 4 (each within the scatter of the next).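

Among the compounds shown here, removing one chloro gives the first direct reading of a single atom at this position in this assay: with hydrogen in place of chloro on an aromatic carbon, there is no change at the digits printed from compound 3 to compound 4 (within the scatter). The 2-chlorophenyl group also keeps the relations seen with 2,6-dichlorophenyl, with an 8.0-fold higher number from compound 2 to compound 4 (0.90 log units; beyond the scatter), which is beyond the scatter, and a 2.0-fold higher number from compound 1 to compound 4 (0.30 log units; within the scatter), which is not, so the 4-(dimethylamino)phenyl group of compound 2 remains the only one here that stands apart from the others. No measurement at hand accounts for the absence of a change on losing this chloro, or for the separate place of compound 2.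

The compounds shown leave open whether taking off the remaining chloro to give a plain phenyl group would also leave the number in place, or whether at least one chloro must stay for that to hold. They also leave open whether the lower number of compound 2 belongs to the dimethylamino group in particular, or would also appear with a simple primary amine or a morpholine in its place.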